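This account rests on a few compounds, and the source may have more. Where it says the series, first, only, none or still open, it means among the compounds named here.

Measured in an assay on isolated protein for inhibition of Ca2+/calmodulin-dependent protein kinase II (CaM kinase II) (Rattus norvegicus), tested at 30 uM; on this read-out lower numbers stand for less inhibition and higher numbers for more inhibition at the one concentration tested (going by the name of the read-out):
compound 1 `c1ccc(Sc2ncnc3[nH]cnc23)cc1` gives 0%
compound 2 `Cn1cnc2c(Sc3ccccc3)ncnc21` gives 8%
compound 3 `Clc1ncnc2c1ncn2Cc1ccccc1` gives 7%

Compound 3 stands second highest of the three numbers; its nearest neighbour is compound 2, its furthest compound 1, and both gaps lie within the scatter. Compound 4 `c1ccc(Cn2cnc3c(Sc4ccccc4)ncnc32)cc1` differs from compound 3 by phenylsulfanyl in place of chloro on an aromatic carbon.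

Going by the values given here, the only measured step is a number 8 percentage points higher from compound 1 to compound 2 (within the scatter), which concerns a methyl on an aromatic nitrogen and does not bear directly on a chloro to phenylsulfanyl exchange. Compounds 1 and 2 both carry phenylsulfanyl on the shared core and give low numbers in this assay, so no step beyond the scatter is expected. Compound 4 is estimated at 5%, range -5% to 15%. The expected step is a number 2 percentage points lower from compound 3 to compound 4 (within the scatter).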

Compound 4, a percentage reported as inhibition, at one concentration (the size of the read-out at that concentration, not a potency): 3%
Compound 4: the middle estimate sits 2 percentage points above what was measured, within the range that was stated.
By their numbers in this assay, from the lowest: compounds 1, 4, 3 and 2 (each within the scatter of the next).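

In this assay, phenylsulfanyl in place of chloro on this aromatic carbon gives a number 4 percentage points lower from compound 3 to compound 4 (within the scatter), so this exchange does not separate the two compounds. On the aromatic nitrogen, benzyl in place of hydrogen gives a number 3 percentage points higher from compound 1 to compound 4 (within the scatter) and phenyl in place of hydrogen on the saturated chain carbon gives a number 5 percentage points lower from compound 2 to compound 4 (within the scatter), so benzyl does not stand apart from hydrogen or methyl there. No measurement on hand speaks to why these numbers stay so close.

From the compounds shown here alone, whether an amine or a carboxylic acid on this aromatic carbon would give a step beyond the scatter remains open.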